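The source may hold more compounds than are shown below. What is called first, only, known or untested is meant among the compounds shown, and "the series" means these compounds.

Measured in an ADME assay on MRC5 cells (Homo sapiens), read by MTT assay, with a stated time of 72 h; a higher number here means a weaker inhibitor, a lower number a stronger inhibitor:

Compound 1 `Nc1nc(N)c2c(-c3ccsc3)cn([C@@H]3O[C@H](CO)[C@@H](O)[C@H]3O)c2n1`: > 100000 nM
Compound 2 `Cc1nc(N)c2c(-c3ccsc3)cn([C@@H]3O[C@H](CO)[C@@H](O)[C@H]3O)c2n1`: > 100000 nM
Compound 3 `Nc1nc2c(c(-c3ccccc3)cn2[C@@H]2O[C@H](CO)[C@@H](O)[C@H]2O)c(=O)[nH]1`: > 100000 nM

For the measured compounds named here, none of these entries is a number, and the limit of > 100000 nM in this assay, at which 3 of the 3 values shown sit, sums up the series so far. Compound 2 gives > 100000 nM, which is a limit of the assay, so its exact standing in this assay cannot be read. Going by the values given here, the one measured step, a step that the two limits leave unreadable from compound 1 to compound 2, concerns methyl in place of amino on an aromatic carbon, and its size cannot be read. Among the compounds with values here, it therefore offers no size to carry forward, and no measured step shows what replacing the thiophen-3-yl group does.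

Compound 4 `Cc1nc(N)c2c(I)cn([C@@H]3O[C@H](CO)[C@@H](O)[C@H]3O)c2n1` has not yet been measured. It differs from compound 2 by iodo in place of thiophen-3-yl on an aromatic carbon, with iodo in place of thiophen-3-yl on an aromatic carbon. With only a limit for compound 2 at > 100000 nM, any readable change could run only toward a lower number, and a further limit remains quite possible. The expected change is an at least 1.6-fold lower number from compound 2 to compound 4 (0.22 log units; that floor lies within the scatter), a loose expectation toward a stronger reading. For compound 4 the estimated value is 60000 nM, with an expected range from 8000 nM to 100000 nM.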

Compound 4, half-maximal inhibitory concentration: 85800 nM
For compound 4 the middle estimate is 1.4-fold (0.16 log units) below the measured one; low and high end bracket the measured number.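

In this assay, for the compounds shown here, compound 4 gives the first readable number, showing that a reading within the range of the assay is possible with a group on this aromatic carbon, two ring bonds from the ring nitrogen. Iodo in place of thiophen-3-yl gives an at least 1.1-fold lower number from compound 2 to compound 4 (0.06 log units; that floor lies within the scatter), so the step shows only a floor that does not clear the usual scatter, and no real gain in strength is established. The other compounds still give no number to set beside compound 4: the limit of > 100000 nM in this assay, at which 3 of the 4 values shown sit.

Going by these compounds alone, how large the true step from thiophen-3-yl to iodo might be remains open, since only the one side of it is a number. Also open, as far as these compounds go, is whether a smaller halogen such as chloro, an amine or a short chain such as ethyl on this carbon would move the reading further, and whether amino in place of methyl would change it once iodo is present.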